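The source may report more compounds than this note shows. Statements on the series, on what has been measured and on what is new or still open speak of the compounds shown alone.

Measured compounds:
compound 1 `COc1cc(-c2nn(-c3cccc(NC(=O)Nc4ccc(Cl)c(Cl)c4)c3)cc2-c2ccncc2)ccc1Cl` with 4590 nM in a functional assay on A498 cells (Homo sapiens) for inhibition, read by sulforhodamine B assay, with a stated time of 48 h; a lower number here means a stronger inhibitor of growth, a higher number a weaker inhibitor of growth;
compound 2 `O=C(Nc1cccc(-n2cc(-c3ccncc3)c(-c3ccc(Cl)c(O)c3)n2)c1)Nc1ccc(Cl)c(Cl)c1` with 3170 nM;
compound 3 `O=C(Nc1cccc(-n2cc(-c3ccncc3)c(-c3ccc(Cl)c(O)c3)n2)c1)Nc1cc(C(F)(F)F)cc(C(F)(F)F)c1` with 4330 nM.

Compound 1 has the highest of the three numbers in this assay, but the gap to compound 3 and the gap to compound 2 both stay inside the usual scatter, so no order among the three can be claimed. For the measured compounds named here, the one measured step that differs in a single place, a 1.4-fold lower number from compound 1 to compound 2 (0.16 log units; within the scatter), concerns the methyl on an oxygen of the shared core and is itself within the scatter. Compound 4 `COc1cc(-c2nn(-c3cccc(NC(=O)c4ccccc4)c3)cc2-c2ccncc2)ccc1Cl` carries a different change: phenyl in place of (3,4-dichlorophenyl)amino on a carbonyl carbon. Going by the values given here, no measured step bears on this change. Compounds 2 and 3 differ from each other in the ring at the far end of the urea, and compound 2 gives 3170 nM while compound 3 gives 4330 nM, which says little about removing the urea nitrogen altogether. Among the compounds with values here, with a hydrogen-bond donor lost and no precedent in the set, compound 4 is expected to give a higher number, a 2.6-fold higher number from compound 1 to compound 4 (0.42 log units; beyond the scatter), with wide uncertainty. The estimate for compound 4 is 12000 nM, expected to lie between 4000 nM and 40000 nM.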

Compound 4, concentration for total growth inhibition: 3140 nM
For compound 4 the middle estimate is 3.8-fold (0.58 log units) above the measured one; measured number outside the range, below it.
By their numbers in this assay, from the lowest: compounds 4, 2, 3 and 1 (each within the scatter of the next).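

Going from the (3,4-dichlorophenyl)amino to phenyl on the carbonyl carbon gives a 1.5-fold lower number from compound 1 to compound 4 (0.16 log units; within the scatter) in this assay. For the compounds shown here, this is the first measured step at this position, and it shows that the ((3,4-dichlorophenyl)carbamoyl)amino group can be replaced by benzamido, losing the nitrogen with its hydrogen-bond donor and both chlorines, with no difference that can be read beyond the scatter. No measurement available here accounts for this tolerance of the position.

The compounds shown leave open whether any group on this carbonyl carbon would give a number clearly apart from these, for example a short alkyl chain, a cyclohexyl ring or a phenyl bearing a carboxylic acid. They also leave open how benzamido behaves when paired with the hydroxyl of compound 2 in place of the methoxy group of compound 1.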